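Notes on esters of the shared core

A few compounds are considered here, and "the series" means these few. Any claim that something is new, unique, unknown or untested is made for them only; others in the source may bear on it.

Measured in a functional assay on MCF7 cells (Homo sapiens) for antiproliferative activity, read by MTT assay, with a stated time of 72 h; a lower number here means a stronger inhibitor, a higher number a weaker inhibitor:
- compound 1 `CC1=CC[C@H]2[C@H](CC[C@]2(C)O)C(C)(C)[C@@H]1CC[C@H]1[C@]2(C)CC[C@H](OC(=O)c3ccc(C(F)(F)F)cc3)C(C)(C)O[C@H]2CC[C@@]1(C)O`: 23400 nM
- compound 2 `CC1=CC[C@H]2[C@H](CC[C@]2(C)O)C(C)(C)[C@@H]1CC[C@H]1[C@]2(C)CC[C@H](OC(=O)c3ccc(C(F)(F)F)cc3F)C(C)(C)O[C@H]2CC[C@@]1(C)O`: > 50000 nM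

Compound 2 stands at > 50000 nM, which is a limit of the assay and not a number. Compound 3 `CC1=CC[C@H]2[C@H](CC[C@]2(C)O)C(C)(C)[C@@H]1CC[C@H]1[C@]2(C)CC[C@H](OC(=O)c3ccc([N+](=O)[O-])o3)C(C)(C)O[C@H]2CC[C@@]1(C)O` brings (5-nitrofuran-2-yl in place of 2-fluoro-4-(trifluoromethyl)phenyl on a carbonyl carbon), with 5-nitrofuran-2-yl in place of 2-fluoro-4-(trifluoromethyl)phenyl on a carbonyl carbon. Within the data shown here, the only measured step is an at least 2.1-fold higher number from compound 1 to compound 2 (0.32 log units; beyond the scatter), and it bears only loosely on this larger exchange. Compound 3 lacks that fluoro, so a return towards compound 1 at 23400 nM is expected. The expected step is an at least 2.0-fold lower number from compound 2 to compound 3 (0.30 log units; that floor lies within the scatter), towards a lower number in this assay. For compound 3 the estimate is 25000 nM, with an expected range of 9000 nM to 50000 nM.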

Compound 3, half-maximal inhibitory concentration: 21300 nM
Beside the measured number, compound 3's estimate is 1.2-fold (0.07 log units) above it; the range from low to high includes it.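

In this assay, 5-nitrofuran-2-yl on the carbonyl carbon matches 4-(trifluoromethyl)phenyl, with a 1.1-fold lower number from compound 1 to compound 3 (0.04 log units; within the scatter), so two quite different aromatic groups are on a par at this place. Against the fluorinated ester, the same exchange gives an at least 2.3-fold lower number from compound 2 to compound 3 (0.37 log units; beyond the scatter). The value of compound 2 is a limit of the assay and not a number: the limit of > 50000 nM in this assay, at which 1 of the 3 values shown sits.

The compounds shown cannot separate the part played by the nitro group of compound 3 from that of its furan ring. Also open, from the compounds shown here alone, is whether a saturated group such as cyclohexyl, or an amine, would be tolerated on this carbonyl carbon.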